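Replacing fluoro with methoxy in compound 2

A few compounds are considered here, and "the series" means these few. Any claim that something is new, unique, unknown or untested is made for them only; others in the source may bear on it.

In a functional assay on MCF7 cells (Homo sapiens) for inhibition, read by MTT assay, with a stated time of 72 h (on this read-out higher numbers stand for weaker inhibition and lower numbers for stronger inhibition), compound 1 (`COc1cccc(/C=C/C(=O)Nc2cc(OC)c(OC)c(OC)c2)c1`) gives 27000 nM and compound 2 (`C=C(Br)C(=O)Nc1cccc(/C=C/C(=O)Nc2ccc(F)cc2)c1`) gives 13600 nM, two values within the scatter of each other. Compound 3 (`C=C(Br)C(=O)Nc1cccc(/C=C/C(=O)Nc2ccc(C)cc2)c1`) gives 2500 nM, which leaves compound 2 clearly on the weaker side of it. Compound 4 (`C=C(Br)C(=O)Nc1cccc(/C=C/C(=O)Nc2ccc(OC)cc2)c1`) has not yet been measured. Its difference from compound 2 is methoxy in place of fluoro on an aromatic carbon, para to a large group. Within the data shown here, only one measured step bears on this change: methyl in place of fluoro on an aromatic carbon, a 5.4-fold lower number from compound 2 to compound 3 (0.74 log units; beyond the scatter), which lies beyond the scatter. It is a single step, and methoxy is not methyl, so it offers only limited guidance. Going by compound 3 at 2500 nM, a lower number of similar or somewhat smaller size is expected in this assay. The estimated change is a 3.0-fold lower number from compound 2 to compound 4 (0.48 log units; beyond the scatter). For compound 4 the estimated value is 4500 nM, with an expected range from 1500 nM to 14000 nM.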

Compound 4, half-maximal inhibitory concentration: 2500 nM
Compound 4: the middle estimate sits 1.8-fold (0.26 log units) above what was measured, and the stated range covers the measured number.
By their numbers in this assay, from the lowest: compounds 3 and 4 (each within the scatter of the next); then compounds 2 and 1 (each within the scatter of the next).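

In this assay, the change from 4-fluorophenyl to 4-methoxyphenyl gives a 5.4-fold lower number from compound 2 to compound 4 (0.74 log units; beyond the scatter), so a second group, after the methyl of compound 3, now departs from fluoro in the same direction at this position. Methoxy and methyl cannot be told apart here, with no change at the digits printed from compound 3 to compound 4 (within the scatter), so the oxygen of methoxy brings no readable difference from methyl at this place. Nothing in the data explains why fluoro stands apart from these two groups.

From the compounds shown here alone, with only fluoro, methyl and methoxy to compare at this position, it remains open how an amine, a carboxylic acid or a longer chain such as ethoxy would read. Going by these compounds, it is also open whether chloro would fall with fluoro or with the other two groups.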